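Removing the amino group from the furanyl analogue

A few compounds are considered here, and "the series" means these few. Any claim that something is new, unique, unknown or untested is made for them only; others in the source may bear on it.

Compound 3 `COc1nc(N)nc2c1c(-c1ccco1)cn2[C@@H]1O[C@H](CO)[C@@H](O)[C@H]1O` is known in a functional assay on HepG2 cells (Homo sapiens) for antiproliferative activity, read by XTT assay, with a stated time of 72 h (a higher number here means a weaker inhibitor, a lower number a stronger inhibitor), only as a limit: compound 3 gives > 20000 nM, which is the limit of > 20000 nM in this assay, at which 1 of the 3 values shown sits. Compound 1 `COc1ncnc2c1c(-c1cccs1)cn2[C@@H]1O[C@H](CO)[C@@H](O)[C@H]1O` gives 13900 nM and compound 2 `C#Cc1cn([C@@H]2O[C@H](CO)[C@@H](O)[C@H]2O)c2ncnc(OC)c12` gives 12700 nM. Among the measured compounds shown here, the one measured step, a 1.1-fold lower number from compound 1 to compound 2 (0.04 log units; within the scatter), sits at a different position on the shared core and so does not bear on the change at hand. Compound 4 `COc1ncnc2c1c(-c1ccco1)cn2[C@@H]1O[C@H](CO)[C@@H](O)[C@H]1O` differs from compound 3 by hydrogen in place of amino on an aromatic carbon. For the measured compounds named here, no measured pair isolates this change; compound 1 and compound 2 both carry hydrogen at that position and give values within the scatter of each other, while compound 3, carrying amino, reports only a limit. Compound 4 is therefore expected to return a number rather than a limit, in the neighbourhood of compound 1 and compound 2. The step of an at least 1.4-fold lower number from compound 3 to compound 4 (0.15 log units; that floor lies within the scatter) is expected to run toward a lower number, though its size cannot be fixed from a limit. Compound 4 is estimated at 14000 nM, within 6000 nM to 30000 nM.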

Compound 4, half-maximal inhibitory concentration: 300 nM
Compound 4: middle estimate off by 47-fold (1.67 log units), on the high side; the measured number lies below the stated range.
By their numbers in this assay, from the lowest: compound 4; then compounds 2 and 1 (each within the scatter of the next). At a limit, above all of these: compound 3.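

In this assay compound 3 is held only as a limit: the limit of > 20000 nM in this assay, at which 1 of the 4 values shown sits.

Even so, an at least 66-fold lower number from compound 3 to compound 4 (1.82 log units; beyond the scatter) shows that this carbon between two ring nitrogen atoms is sensitive to substitution, with hydrogen in place of amino giving a large step on the furan-2-yl compounds. The group on the other aromatic carbon also proves to matter when hydrogen occupies this position: furan-2-yl gives a 42-fold lower number from compound 2 to compound 4 (1.63 log units; beyond the scatter) and a 46-fold lower number from compound 1 to compound 4 (1.67 log units; beyond the scatter), although the earlier step between the thiophen-2-yl and ethynyl compounds gave no sign of such a spread.

As far as these compounds go, the amino change is read on the furan-2-yl compounds alone, so its size with thiophen-2-yl or ethynyl remains open. From the compounds shown here alone, how a methyl group, a chlorine atom or a methylamino group at this carbon would read also remains open.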